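This account rests on a few compounds, and the source may have more. Where it says the series, first, only, none or still open, it means among the compounds named here.

Measured in a functional assay on MGC-803 cells (Homo sapiens) for inhibition; a lower number here means a stronger inhibitor, a higher number a weaker inhibitor:
- compound 1 `CCN(CC)CCNC(=O)CC(CC(=O)NC1Cc2ccccc2C1)c1ccc(Cl)cc1`: > 100000 nM, a limit
- compound 2 `O=C(CC(CC(=O)NC1Cc2ccccc2C1)c1ccc(Cl)cc1)NCCN1CCCC1`: > 100000 nM, a limit
- compound 3 `CCN(CC)CCNC(=O)CC(CC(=O)NC1Cc2ccccc2C1)c1ccccc1`: > 100000 nM, a limit

Compound 1 thus stands only at a limit, > 100000 nM, and no number is known for it. Compound 4 `CCN(CC)CCNC(=O)CC(CC(=O)N(CC)C1Cc2ccccc2C1)c1ccc(Cl)cc1` differs from it by ethyl in place of hydrogen on an amide-type nitrogen. Going by the values given here, two measured steps bear on this only loosely: a step that the two limits leave unreadable from compound 1 to compound 2 and a step that the two limits leave unreadable from compound 1 to compound 3. Both changes lie elsewhere in the molecule, and neither has a readable size. All that the series offers is the limit of > 100000 nM in this assay, at which 3 of the 3 values shown sit. No direction can be drawn from this, so no step beyond the scatter is expected, and the estimated change is a number no higher from compound 1 to compound 4 (the limit leaves the size open). The estimate for compound 4 is 100000 nM, expected between 30000 nM and 300000 nM.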

Compound 4, half-maximal inhibitory concentration: 44900 nM
The estimate for compound 4 lay 2.2-fold (0.35 log units) above the measured number; low and high end bracket the measured number.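

In this assay, the amide-type nitrogen whose other neighbours are a carbonyl carbon and a saturated ring carbon is the one place shown where a change gives a readable result: ethyl in place of hydrogen there gave an at least 2.2-fold lower number from compound 1 to compound 4 (0.34 log units; beyond the scatter). Compound 4 is the only compound shown with an actual number. The step has a floor but no exact size, and the other steps cannot be read, since the series rests largely on a limit: the limit of > 100000 nM in this assay, at which 3 of the 4 values shown sit.

On these data alone, whether methyl or a longer chain such as propyl on this nitrogen would give a lower or higher number remains open. Also open, as far as these compounds go, is whether ethyl here would have the same effect alongside pyrrolidin-1-yl in place of diethylamino, or hydrogen in place of chloro.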